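A few compounds are considered here, and "the series" means these few. Any claim that something is new, unique, unknown or untested is made for them only; others in the source may bear on it.

Compound 1 `O=C(O)c1cc(=O)c2ccc(OCCCCCSc3ccccc3)cc2o1` has 0.4 ug/mL
Compound 2 `O=C(O)c1cc(=O)c2ccc(OCCCCCOc3cccc(O)c3)cc2o1` has 1.5 ug/mL

In a functional assay on ileum (Cavia porcellus) for antagonist activity, with a stated time of 30 s (a higher number here means a weaker inhibitor, a lower number a stronger inhibitor), compound 2 sits at 1.5 ug/mL as the higher of the two numbers, which makes it the weaker inhibitor of the pair. Compound 3 `CC(=O)c1ccc(OCCCCCOc2ccc3c(=O)cc(C(=O)O)oc3c2)cc1` differs from compound 2 by 4-acetylphenyl in place of 3-hydroxyphenyl on an oxygen on a saturated carbon and this reads as 4-acetylphenyl in place of 3-hydroxyphenyl on an oxygen on a saturated carbon. Within the data shown here, the one measured step that bears on this is a 3.8-fold higher number from compound 1 to compound 2 (0.57 log units; beyond the scatter) and it is modest. It gives a rough size but no direction for the new group. A small shift is therefore expected, with the estimated change being a 1.5-fold lower number from compound 2 to compound 3 (0.18 log units; within the scatter) in this assay and leaning slightly lower. Compound 3 is estimated at 1 ug/mL with a range from 0.3 ug/mL to 3.5 ug/mL expected.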

Compound 3, half-maximal inhibitory concentration: 3.5 ug/mL
For compound 3 the middle estimate is 3.5-fold (0.54 log units) below the measured one; measured number inside the range.
By their numbers in this assay, from the lowest: compound 1; then compound 2; then compound 3.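

Within this assay the end group on the chain matters: there is a 2.3-fold higher number from compound 2 to compound 3 (0.37 log units; beyond the scatter) when 4-acetylphenyl replaces 3-hydroxyphenyl, and an 8.8-fold higher number from compound 1 to compound 3 (0.94 log units; beyond the scatter) when 4-acetylphenoxy replaces phenylsulfanyl. The first pair changed the linking atom and the ring together, whereas this step keeps the oxygen link and changes only the ring, so the ring alone can shift the number, and compound 3 is the weakest inhibitor of the three. No measurement shown gives a reason for these shifts.

From the compounds shown here alone, whether the shift follows the gain of the acetyl group, the loss of the hydroxyl or the place each occupies on the ring stays open. A plain phenoxy end, a ring bearing an amine or a longer chain would test these questions further.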